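Anilide swap on a fused bicyclic series: notes toward compound 4

The source may report more compounds than this note shows. Statements on the series, on what has been measured and on what is new or still open speak of the compounds shown alone.

Measured so far in a functional assay on NCI-H661 cells (Homo sapiens) for cytotoxicity, read by WST assay, with a stated time of 72 h; a lower number here means a stronger inhibitor, a higher number a weaker inhibitor:
- compound 1 `COc1cc2c(Nc3nc4ccc(C(=O)Nc5c(C)cc(C)cc5C)cc4s3)ncnc2cc1OCCCN1CCC(C)CC1`: 7700 nM
- compound 2 `COc1cc2c(Nc3nc4ccc(C(=O)Nc5c(C)cccc5C)cc4s3)ncnc2cc1OCCCN1CCCCC1`: a limit, > 100000 nM
- compound 3 `COc1cc2c(Nc3nc4ccc(C(=O)Nc5c(C)cccc5Cl)cc4s3)ncnc2cc1OCCCN1CCCCC1`: 13800 nM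

Compound 3 holds the highest of the two numbers given; compound 1 sits a step away that lies within the scatter. Compound 2 gives only a limit, as noted in the limit of > 100000 nM in this assay, at which 1 of the 3 values shown sits.

Among the measured compounds shown here, the one measured step, an at least 7.2-fold lower number from compound 2 to compound 3 (0.86 log units; beyond the scatter), turns a limit into a number and is at least modest.

Compound 4 `COc1cc2c(Nc3nc4ccc(C(=O)Nc5c(C)cc(C)cc5C)cc4s3)ncnc2cc1OCCCN1CCCCC1` differs from compound 3 by 2,4,6-trimethylphenyl in place of 2-chloro-6-methylphenyl on an amide-type nitrogen. For the measured compounds named here, no measured step covers this exact exchange; compound 1, which also carries the 2,4,6-trimethylphenyl group, gives 7700 nM, close to compound 3. A small shift, if any, is therefore expected in this assay.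

Compound 4 is estimated at 10000 nM, in the range 3000 nM to 40000 nM. The expected step is a 1.4-fold lower number from compound 3 to compound 4 (0.14 log units; within the scatter), likely within the scatter.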

Compound 4, half-maximal inhibitory concentration: 10000 nM
Estimate against measurement, compound 4: no gap at the digits printed; low and high end bracket the measured number.
By their numbers in this assay, from the lowest: compounds 1, 4 and 3 (each within the scatter of the next). At a limit, above all of these: compound 2.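

In this assay, 2,4,6-trimethylphenyl and 2-chloro-6-methylphenyl on the amide-type nitrogen cannot be told apart, with a 1.4-fold lower number from compound 3 to compound 4 (0.14 log units; within the scatter). Methyl in place of hydrogen on an aromatic carbon gives an at least 10-fold lower number from compound 2 to compound 4 (1.00 log units; beyond the scatter), a step read from a limit: the limit of > 100000 nM in this assay, at which 1 of the 4 values shown sits. Hydrogen in place of methyl on a saturated ring carbon gives a 1.3-fold higher number from compound 1 to compound 4 (0.11 log units; within the scatter), so this change also stays within the scatter.

Still open, from the compounds shown here alone, is whether a group carrying an amine or a carboxylic acid, in place of 2,4,6-trimethylphenyl on the amide-type nitrogen, would move the number beyond the scatter.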